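The source may hold more compounds than are shown below. What is called first, only, known or untested is meant among the compounds shown, and "the series" means these compounds.

Working notes on the side chain of the series, read in an ADME assay on microsomes from liver (Homo sapiens) for metabolic stability, read by LC-MS, tested at 1 uM; on this read-out higher numbers stand for fast clearance and lower numbers for slow clearance. Compound 1 (`c1cc([C@H]2CC[C@]3(CC2)OOC2(O3)C3CC4CC(C3)CC2C4)ccc1OCCCNC1CCOCC1`) gives 10 mL.min-1.g-1 and compound 3 (`OC1(COc2ccc([C@H]3CC[C@]4(CC3)OOC3(O4)C4CC5CC(C4)CC3C5)cc2)CCNCC1`) gives 16 mL.min-1.g-1, so the two stand level within the scatter. Compound 2 (`c1cc([C@H]2CC[C@]3(CC2)OOC2(O3)C3CC4CC(C3)CC2C4)ccc1OCCOC1CCNCC1`) reports < 7 mL.min-1.g-1, which is a limit of the assay and not a number.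

The next change leads to compound 4 (`CC(C)(N)CCOc1ccc([C@H]2CC[C@]3(CC2)OOC2(O3)C3CC4CC(C3)CC2C4)cc1`), with 2-amino-2-methylpropyl in place of 4-hydroxypiperidin-4-yl on a saturated chain carbon bound to an oxygen on an aromatic ring. Among the compounds with values here, no measured step swaps these two groups. The nearest guides are the other side-chain changes: a 1.6-fold higher number from compound 1 to compound 3 (0.20 log units; within the scatter), an at least 1.4-fold lower number from compound 1 to compound 2 (0.15 log units; that floor lies within the scatter) and an at least 2.2-fold higher number from compound 2 to compound 3 (0.35 log units; beyond the scatter). Only the last lies beyond the scatter, and it is measured against a limit. A step within the scatter is therefore expected in this assay, with no firm direction. The estimate amounts to an expected 1.3-fold lower number from compound 3 to compound 4 (0.12 log units; within the scatter). Compound 4 is expected at 12 mL.min-1.g-1, with an estimated range of 7 mL.min-1.g-1 to 25 mL.min-1.g-1.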

Compound 4, intrinsic clearance in microsomes: < 7 mL.min-1.g-1
Compound 4: no number, only a limit; the forecaster's own chance of this, stated with the estimate: 20%; at least 1.7-fold (0.23 log units) between middle value and limit.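

In this assay, 2-amino-2-methylpropyl in place of 4-hydroxypiperidin-4-yl, on a saturated chain carbon bound to an oxygen on an aromatic ring, gives an at least 2.2-fold lower number from compound 3 to compound 4 (0.35 log units; beyond the scatter), so a swap at this position that leaves the ring out now moves the read-out beyond the scatter, though the reading for compound 4 is a limit and not a number. The comparison with the other side chain is weaker: an at least 1.4-fold lower number from compound 1 to compound 4 (0.15 log units; that floor lies within the scatter). The step between compound 2 and compound 4 cannot be read because both report a limit: the limit of < 7 mL.min-1.g-1 in this assay, at which 2 of the 4 values shown sit.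

Going by these compounds, how far compound 4 lies under its limit, and how it ranks against compound 2, stays open. Also open, on these data alone, is whether the lower number follows the open chain or its two methyl groups, which an unbranched aminobutyl chain or a piperidine without the hydroxyl would help to separate.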